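This account rests on a few compounds, and the source may have more. Where it says the series, first, only, none or still open, it means among the compounds named here.

Measured so far in a functional assay on Right cardiac atrium for agonist activity at histamine H2 receptor (Cavia porcellus), with a stated time of 30 min, in the presence of a further agent that is not named here; on this read-out lower numbers stand for an effect already at smaller amounts and higher numbers for an effect only at larger amounts of compound:
- compound 1, `Cc1nc(N)sc1CCCN/C(N)=N/C(=O)NCc1ccco1`: 11.8 nM
- compound 2, `Cc1ccc(C(C)NC(=O)/N=C(\N)NCCCc2sc(N)nc2C)cc1`: 22.4 nM
- compound 3, `Cc1nc(N)sc1CCCN/C(N)=N/C(=O)NC(C)c1cccs1`: 10 nM

Compound 3 gives the lowest number of the three, but its gap to compound 1 lies within the scatter of this assay; only compound 2 sits clearly apart, as the step of a 2.2-fold lower number from compound 2 to compound 3 (0.35 log units; beyond the scatter) shows. Compound 4, `Cc1nc(N)sc1CCCN/C(N)=N/C(=O)NC(C)c1ccco1`, differs from compound 3 in one place: furan-2-yl in place of thiophen-2-yl on a saturated chain carbon bound to an amide-type nitrogen and a saturated chain carbon.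

Within the data shown here, two measured steps bear on this change. The step of a 1.2-fold lower number from compound 1 to compound 3 (0.07 log units; within the scatter) exchanges the furan ring together with the methylene for the thiophene ring with the ethyl link, and the number barely moves. The step of a 2.2-fold lower number from compound 2 to compound 3 (0.35 log units; beyond the scatter) replaces a 4-methylphenyl ring by thiophen-2-yl at the same chain carbon and gives a modest gain. The swap of thiophene for furan with the ethyl link kept is therefore expected to move this assay little, and a step of a 1.3-fold higher number from compound 3 to compound 4 (0.11 log units; within the scatter) is estimated. Compound 4 is thus expected to give about 13 nM, within 6 nM to 30 nM.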

Compound 4, half-maximal effective concentration: 9.77 nM
Compound 4: middle estimate off by 1.3-fold (0.12 log units), on the high side, within the range that was stated.
By their numbers in this assay, from the lowest: compounds 4, 3, 1 and 2 (each within the scatter of the next, the first and the last beyond it).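

In this assay, the direct exchange of thiophen-2-yl for furan-2-yl with the ethyl link kept, a 1.0-fold lower number from compound 3 to compound 4 (0.01 log units; within the scatter), shows that the two rings cannot be told apart at this position. The step of a 1.2-fold lower number from compound 1 to compound 4 (0.08 log units; within the scatter) isolates methyl in place of hydrogen on the saturated chain carbon and also stays within the scatter, whereas the earlier step to compound 3 had changed the ring and this methyl together. The step of a 2.3-fold lower number from compound 2 to compound 4 (0.36 log units; beyond the scatter) shows that furan-2-yl, like thiophen-2-yl, stands apart from 4-methylphenyl at this carbon, though only modestly.

Nothing at hand gives a reason for any of these steps. On these data alone, it remains open whether a pyridine ring in place of furan-2-yl, or an ethyl group in place of the methyl, would keep the number at this level.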